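This account rests on a few compounds, and the source may have more. Where it says the series, first, only, none or still open, it means among the compounds named here.

Of the compounds shown here, three built on one shared core have been measured in an in vitro ADME assay on microsomes (Rattus norvegicus) for metabolic stability; on this read-out higher numbers stand for a longer-lived compound and lower numbers for a shorter-lived compound. Compound 1 `CCc1nc(-c2ccc(Cl)cc2Cl)c(CC)nc1NC(COC)COC` gives 0.0417 h, compound 2 `CCc1nc(-c2ccc(OC)cc2O)c(CC)nc1NC(CC)CC` gives 0.0983 h, and compound 3 `CCc1nc(-c2ccc(Cl)cc2Cl)c(CC)nc1NC(C1CC1)C1CC1` gives 0.0417 h. Compound 3 therefore stands level with compound 1, and together these two hold the lowest numbers of the three; compound 2 is the furthest from compound 3, and that gap lies beyond the scatter.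

Going by the values given here, only one measured step changes a single group on this core: no change at the digits printed from compound 1 to compound 3 (within the scatter), which put dicyclopropylmethyl in place of 2-methoxy-1-(methoxymethyl)ethyl on the nitrogen attached to the aromatic ring and left the half-life where it was.

Compound 4 `CCc1nc(N(CC2CC2)CC2CC2)c(CC)nc1-c1ccc(Cl)cc1Cl` differs from compound 3 by bis(cyclopropylmethyl)amino in place of (dicyclopropylmethyl)amino on an aromatic carbon, on an aromatic carbon of the core para to the 2,4-dichlorophenyl group. Among the compounds with values here, no measured pair shows the loss of the amine hydrogen or the move to two cyclopropylmethyl arms, so the flat step between compound 1 and compound 3 is the only guide, and compound 2 carries a different aryl group as well. Compound 4 is expected to show no step beyond the scatter, a 1.1-fold higher number from compound 3 to compound 4 (0.03 log units; within the scatter). Compound 4 is estimated at 0.045 h, within 0.02 h to 0.1 h.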

Compound 4, half-life: < 0.0167 h
Compound 4: a limit, no number; the forecaster's own chance of this, stated with the estimate: 20%; at least 2.6-fold (0.43 log units) between middle value and limit.
By their numbers in this assay, from the lowest: compounds 1 and 3 (each within the scatter of the next); then compound 2. At a limit, below all of these: compound 4.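

In this assay compound 4 gives < 0.0167 h, which is a limit of the assay and not a number. Going by these compounds alone, the position on the aromatic carbon of the shared core had looked indifferent to its substituent, with no change at the digits printed from compound 1 to compound 3 (within the scatter), but putting bis(cyclopropylmethyl)amino in place of (dicyclopropylmethyl)amino gives an at least 2.4-fold lower number from compound 3 to compound 4 (0.39 log units; beyond the scatter), the first change at this position to reach beyond the scatter. The comparison with the ether-bearing amine reads the same way, with an at least 2.4-fold lower number from compound 1 to compound 4 (0.39 log units; beyond the scatter), so compounds 1 and 3, which both keep the amine hydrogen, stand on one side of this step and compound 4, which has lost it and carries its two cyclopropylmethyl arms on the nitrogen, on the other.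

The compounds shown leave open whether the loss of the amine hydrogen or the change in the arms carries the step, a question that an amine with a single cyclopropylmethyl arm and its hydrogen kept, or a tertiary amine with two ethyl arms, would help to separate. How far the half-life of compound 4 really lies under the other values also stays open, and the data mark only where reading ends: the limit of < 0.0167 h in this assay, at which 1 of the 4 values shown sits.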